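This account rests on a few compounds, and the source may have more. Where it says the series, first, only, none or still open, it means among the compounds named here.

Three measured compounds share a chalcone-type frame and are compared in an ADME assay on THP-1 cells (Homo sapiens) for cytotoxicity, read by resazurin assay, with a stated time of 72 h; on this read-out lower numbers stand for higher toxicity in this test and higher numbers for lower toxicity in this test. Compound 1 `COc1cc(OCC=C(C)C)ccc1C(=O)/C=C/c1cccnc1` gives 40000 nM in this assay. Compound 2 `COc1cc(OCC=C(C)C)ccc1C(=O)/C=C/c1ccc(Br)cc1` gives 100000 nM in this assay. Compound 3 `C#CCOc1ccc(C(=O)/C=C/c2cccnc2)c(OCC#C)c1` gives 15000 nM in this assay, the lowest of the three numbers. The difference between the core of compound 1 and the core of compound 3 is not broken down here.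

Going by the values given here, the only single-point change among the measured compounds is the one from compound 1 to compound 2: 4-bromophenyl in place of pyridin-3-yl on a double-bonded chain carbon bound to a double-bonded chain carbon In this assay that change gave a 2.5-fold higher number from compound 1 to compound 2 (0.40 log units; beyond the scatter), a modest shift toward a higher number.

The unmeasured compound 4 `C#CCOc1ccc(C(=O)/C=C/c2ccc(Br)cc2)c(OCC#C)c1` carries the same change, now made on the core of compound 3: 4-bromophenyl in place of pyridin-3-yl on a double-bonded chain carbon bound to a double-bonded chain carbon The place of the change is described in the same words for both pairs, so this is the same change made on a different core.

The expectation rests on what the change did once before: since the step from compound 1 to compound 2 in this assay was a 2.5-fold higher number from compound 1 to compound 2 (0.40 log units; beyond the scatter), the step from compound 3 to compound 4 in this assay is expected to be a 2.3-fold higher number from compound 3 to compound 4 (0.37 log units; beyond the scatter), a shift of similar size and direction. With that, compound 4 is estimated to give 35000 nM in this assay, most likely falling between 15000 nM and 90000 nM, with the range left wide since a single earlier step is a thin basis and the two cores are not compared point by point.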

Compound 4, half-maximal cytotoxic concentration: 25000 nM
Estimate against measurement, compound 4: 1.4-fold (0.15 log units) above, within the range that was stated.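

On the core of compound 3, putting 4-bromophenyl in place of pyridin-3-yl gave, in this assay, a 1.7-fold higher number from compound 3 to compound 4 (0.22 log units; within the scatter), a step that on its own cannot be told apart from the ordinary spread of repeated measurements. Set beside the earlier step, the two results are close enough to count as the same within that spread: the same change on two cores in this assay, a 2.5-fold higher number (0.40 log units; beyond the scatter) from compound 1 to compound 2 and a 1.7-fold higher number (0.22 log units; within the scatter) from compound 3 to compound 4, 1.5-fold (0.18 log units) apart, within the scatter of two such steps. Going by these compounds alone, this shows that, for these two cores, the effect of the change on one core gave a usable guide to its effect on the other, but it does not show a dependable rise on every core, since only one of the two steps lies beyond the scatter, and two pairs are too few to support a rule for the wider series.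

The compounds shown leave open whether the same change would behave alike on a core carrying a longer chain, such as a hexyloxy group, in place of the chains found here. They also leave open how this assay would respond if the ring at this place carried an amine or a carboxylic acid, rather than being pyridin-3-yl or 4-bromophenyl.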